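This account rests on a few compounds, and the source may have more. Where it says the series, first, only, none or still open, it means among the compounds named here.

Compound 1 `COc1ccc(Cn2cc(/C=N\NC(=O)c3c[nH]c4ccccc34)c3cc(OC)ccc32)cc1` was tested in a functional assay on LNCaP cells (Homo sapiens) for cytotoxicity; a higher number here means a weaker inhibitor, a lower number a stronger inhibitor. In this assay compound 1 gives > 100000 nM, which is a limit of the assay rather than a number. Compound 2 `COc1ccc(Cn2cc(/C=N\NC(=O)c3c[nH]c4ccc(Br)cc34)c3cc(OC)ccc32)cc1` carries a bromo group on the same core; in this assay compound 2 gives > 100000 nM, again only a limit. The step that the two limits leave unreadable from compound 2 to compound 1 therefore cannot be read, the change being (hydrogen in place of bromo on an aromatic carbon). Compound 3 `COc1ccc(Cn2cc(/C=N\NC(=O)c3c[nH]c4ccc(Br)cc34)c3ccc(F)cc32)cc1` is built on a different core; how its core differs from that of compound 2 is not broken down here. In this assay compound 3 gives > 100000 nM, once more a limit. Among the compounds with values here, every value measured so far sits at the limit of > 100000 nM in this assay, at which 3 of the 3 values shown sit. Compound 4 `COc1ccc(Cn2cc(/C=N\NC(=O)c3c[nH]c4ccccc34)c3ccc(F)cc32)cc1` is not yet measured. It differs from compound 3 by hydrogen in place of bromo on an aromatic carbon, the same change as from compound 2 to compound 1, made at the same place. Within the data shown here, the step of a number no higher from compound 3 to compound 4 (the limit leaves the size open) is an expectation only, resting on the fact that every value so far sits at the limit of > 100000 nM in this assay, at which 3 of the 3 values shown sit. Compound 4 is expected to give about 100000 nM, with a likely range from 30000 nM to 300000 nM, most probably reported again as a limit.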

Compound 4, half-maximal inhibitory concentration: > 100000 nM
Compound 4: only a limit was reported; the forecaster's own chance of this, stated with the estimate: 85%; the middle value lies on the limit itself.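

In this assay compound 4 gives > 100000 nM, which is again only a limit. The step from compound 3 to compound 4 therefore cannot be read, and neither can the matching step from compound 2 to compound 1. Compounds 1 to 4 leave open whether swapping bromo for hydrogen changes the cytotoxicity at all, since all of them share one ceiling: the limit of > 100000 nM in this assay, at which 4 of the 4 values shown sit.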